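A Third Methoxy Group on the Ketone Side Ring

The source may report more compounds than this note shows. Statements on the series, on what has been measured and on what is new or still open speak of the compounds shown alone.

Of the compounds shown here, three have been measured. In a functional assay on TK-10 cells (Homo sapiens) for inhibition, read by sulforhodamine B assay, with a stated time of 48 h (a higher number here means a weaker inhibitor of growth, a lower number a stronger inhibitor of growth), compound 1 `COc1cc(-c2cc(/C=C/C(=O)c3ccc(N)cc3)[nH]n2)cc(OC)c1OC` gives 4840 nM. Compound 2 `COc1ccc(C(=O)/C=C/c2cc(-c3cc(OC)c(OC)c(OC)c3)n[nH]2)cc1OC` gives 1330 nM in this assay. Compound 3 `COc1ccc(-c2cc(/C=C/C(=O)c3ccc(N)cc3)[nH]n2)cc1OC` gives 1090 nM in this assay.

Compound 2 and compound 3 differ in their cores, and that difference is not broken down here; what their two numbers show is that they lie within the usual scatter of one another, so no order can be read between them. Compound 1 is reached from compound 3 by methoxy in place of hydrogen on an aromatic carbon, and this change gave a 4.4-fold higher number from compound 3 to compound 1 (0.65 log units; beyond the scatter). Compound 2 is reached from compound 1 by a different change, 3,4-dimethoxyphenyl in place of 4-aminophenyl on a carbonyl carbon, which gave a 3.6-fold lower number from compound 1 to compound 2 (0.56 log units; beyond the scatter).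

Compound 4 `COc1cc(C(=O)/C=C/c2cc(-c3cc(OC)c(OC)c(OC)c3)n[nH]2)cc(OC)c1OC` has not yet been measured. It differs from compound 2 by methoxy in place of hydrogen on an aromatic carbon. Within the data shown here, this is the same change that leads from compound 3 to compound 1, made at a place described in the same words, so the one measured instance of it is the only guide available. On that basis the step from compound 2 to compound 4 is expected to be a 3.6-fold higher number from compound 2 to compound 4 (0.56 log units; beyond the scatter), resting on the earlier step of a 4.4-fold higher number from compound 3 to compound 1 (0.65 log units; beyond the scatter) seen from compound 3 to compound 1. Compound 4 is therefore estimated at 4800 nM in this assay, with a likely range from 1900 nM to 12000 nM.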

Compound 4, concentration for 50% growth inhibition: 1460 nM
For compound 4 the middle estimate is 3.3-fold (0.52 log units) above the measured one, and the stated range ends above it.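

In this assay, methoxy in place of hydrogen on an aromatic carbon gave a 1.1-fold higher number from compound 2 to compound 4 (0.04 log units; within the scatter), so no order can be read between these two compounds. Set beside the earlier instance, the same named change did not keep its size from one core to the other: the same change on two cores in this assay, a 4.4-fold higher number (0.65 log units; beyond the scatter) from compound 3 to compound 1 and a 1.1-fold higher number (0.04 log units; within the scatter) from compound 2 to compound 4, 4.0-fold (0.61 log units) apart, beyond the scatter of two such steps. This shows that, in this series, a step measured on the core of compound 3 cannot be assumed to hold on the core of compound 2, but two instances do not show what sets the size of the step, whether the difference between the cores or the exact place of the new methoxy group, or how the change would behave on any further core.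

The compounds shown leave open whether a hydroxy group, an ethoxy group or a fluorine atom in place of the added methoxy group would give steps that differ between the two cores in the same way. They also leave open whether an amine other than the primary amino group of compound 1 and compound 3, such as a dimethylamino group, would give a step closer to the one on the core of compound 1 or the one on the core of compound 2.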